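Fluoro to Chloro on the Aryl Ring of Compound 2

This account rests on a few compounds, and the source may have more. Where it says the series, first, only, none or still open, it means among the compounds named here.

Compound 1 `COc1ccc2cc([C@H](C)c3nnc(SCc4ccccc4)n3-c3ccc(Cl)cc3)ccc2c1`: 35800 nM
Compound 2 `COc1ccc(CSc2nnc([C@@H](C)c3ccc4cc(OC)ccc4c3)n2-c2ccc(F)cc2)cc1`: <= 400000 nM
Compound 3 `COc1ccc2cc([C@H](C)c3nnc(SCc4c(Cl)cccc4Cl)n3-c3ccc(F)cc3)ccc2c1`: 12300 nM

In a functional assay on DU-145 cells (Homo sapiens) for cytotoxicity, read by MTT assay (a lower number here means a stronger inhibitor, a higher number a weaker inhibitor), compound 2 is known only by a limit, <= 400000 nM, which is one of the values caught at the limit of <= 400000 nM in this assay, at which 1 of the 3 values shown sits. For the measured compounds named here, compound 1 gives 35800 nM and compound 3 gives 12300 nM; these two differ in two places, so they offer no single step. Going by the values given here, the one step touching compound 2, a step that the limit leaves unreadable from compound 2 to compound 3, is left unreadable by that limit.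

Compound 4 `COc1ccc(CSc2nnc([C@@H](C)c3ccc4cc(OC)ccc4c3)n2-c2ccc(Cl)cc2)cc1` carries chloro in place of fluoro on an aromatic carbon. Among the compounds with values here, no measured step bears on this change, so the expected direction is open and the expected step that the limit leaves unreadable from compound 2 to compound 4 is loose. Compound 4 is estimated at 120000 nM, between 25000 nM and 400000 nM.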

Compound 4, half-maximal inhibitory concentration: 72600 nM
Compound 4: the middle estimate sits 1.7-fold (0.22 log units) above what was measured, and the stated range covers the measured number.
By their numbers in this assay, from the lowest: compound 3; then compound 1; then compound 4.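

In this assay compound 4 gives a measured number, 72600 nM, and this provides the first readable step among these compounds: with the 4-chlorophenyl kept, methoxy in place of hydrogen on an aromatic carbon gives a 2.0-fold higher number from compound 1 to compound 4 (0.31 log units; beyond the scatter). The steps from compound 2 cannot be read, because compound 2 is known only by a limit: the limit of <= 400000 nM in this assay, at which 1 of the 4 values shown sits.

Going by these compounds, what the change from 4-fluorophenyl to 4-chlorophenyl does on its own therefore stays open. Also open, on these data alone, is whether an amine or a carboxylic acid in place of that methoxy would shift the number.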